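Ester side chains on the shared core: working notes

The source may report more compounds than this note shows. Statements on the series, on what has been measured and on what is new or still open speak of the compounds shown alone.

In an ADME assay on HepG2 2.2.15 cells (Homo sapiens) for cytotoxicity (a higher number here means that more compound is tolerated, a lower number that less compound is tolerated), compound 1 (`CC(=O)OCCc1c(-c2ccccc2Cl)c2cc(Cl)ccc2[nH]c1=O`) gives 27000 nM, compound 2 (`CCCCC(=O)OCCc1c(-c2ccccc2Cl)c2cc(Cl)ccc2[nH]c1=O`) gives 200000 nM and compound 3 (`O=C(CN1C(=O)c2ccccc2C1=O)OCCc1c(-c2ccccc2Cl)c2cc(Cl)ccc2[nH]c1=O`) gives 960000 nM, the highest of the three numbers. Compound 4 (`COc1ccccc1/C=C/C(=O)OCCc1c(-c2ccccc2Cl)c2cc(Cl)ccc2[nH]c1=O`), not yet measured, carries a group of 10 heavy atoms (9 carbon, 1 oxygen; one six-membered aromatic ring of carbon only) in place of a group of 12 heavy atoms (9 carbon, 1 nitrogen, 2 oxygen; one five-membered non-aromatic ring with 1 hetero atom, one six-membered aromatic ring of carbon only), on a carbonyl carbon, the entering group being 2-(2-methoxyphenyl)ethenyl. For the measured compounds named here, three measured steps bear on this change: a 7.4-fold higher number from compound 1 to compound 2 (0.87 log units; beyond the scatter), a 36-fold higher number from compound 1 to compound 3 (1.55 log units; beyond the scatter) and a 4.8-fold higher number from compound 2 to compound 3 (0.68 log units; beyond the scatter). All three rise with the larger group on the saturated chain carbon, and none of these compounds goes against that trend. None of them, however, tests the entering group, so the evidence is indirect. Going by the values given here, compound 3 tops the three compounds, and the only measured compounds to compare it with lie lower, so a fall of modest size is the working expectation. The expected change is a 3.8-fold lower number from compound 3 to compound 4 (0.58 log units; beyond the scatter), towards less compound tolerated. For compound 4 the estimated value is 250000 nM, with an expected range of 50000 nM to 900000 nM.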

Compound 4, half-maximal cytotoxic concentration: 770000 nM
For compound 4 the middle estimate is 3.1-fold (0.49 log units) below the measured one, within the range that was stated.
By their numbers in this assay, from the lowest: compound 1; then compound 2; then compounds 4 and 3 (each within the scatter of the next).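

In this assay, 2-(2-methoxyphenyl)ethenyl on the carbonyl carbon stands level with the group it replaces, a 1.2-fold lower number from compound 3 to compound 4 (0.10 log units; within the scatter), so a group with no nitrogen and no five-membered non-aromatic ring reaches the same level as compound 3. The other two steps, a 3.9-fold higher number from compound 2 to compound 4 (0.59 log units; beyond the scatter) and a 29-fold higher number from compound 1 to compound 4 (1.46 log units; beyond the scatter), put the entering group clear of butyl and methyl, and no compound among these four goes against the rise from methyl through butyl to the two ring-bearing groups. Nothing available here accounts for these numbers.

On these data alone, whether the number follows the size of the group or the presence of a ring stays open, and a longer chain such as octyl on the same carbonyl carbon would separate the two. Also open, as far as these compounds go, is how a side chain ending in an amine or a carboxylic acid would read.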